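Working notes: from compound 2 to compound 4

A few compounds are considered here, and "the series" means these few. Any claim that something is new, unique, unknown or untested is made for them only; others in the source may bear on it.

- compound 1 `COc1ccc(C(=NNC(=O)NNC(=O)NCCCC(C)Nc2cc(OC)cc3cccnc23)c2ccc(OC)cc2)cc1`: 1000 nM
- compound 2 `COc1cc(NC(C)CCCNC(=O)NN)c2ncccc2c1`: 16000 nM
- compound 3 `NNC(=O)NC(c1ccccc1)c1ccc(Cl)cc1`: >= 100000 nM

Among the compounds with values here, all three entries come from a functional assay on MCF7 cells (Homo sapiens) for inhibition, read by MTT assay, with a stated time of 4 days (on this read-out lower numbers stand for stronger inhibition and higher numbers for weaker inhibition), and no step in a single place joins them. Compound 3 stands at (>= 100000 nM) and this is a limit of the assay, not a number. Of the two true numbers, compound 2 (16000 nM) holds the higher, and its gap to compound 1 (1000 nM) lies beyond the scatter.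

In this assay compound 4 `COc1cc(NC(C)CCCNC(=O)NNC(=O)NCCCO)c2ncccc2c1` is still unmeasured. The change from compound 2 is (3-hydroxypropyl)carbamoyl in place of hydrogen on an amine nitrogen and amounts to (3-hydroxypropyl)carbamoyl in place of hydrogen on an amine nitrogen. Within the data shown here, no measured pair isolates this change, so the expectation is loose. A modest move toward a lower number is expected, perhaps not beyond the scatter, as compound 1 (1000 nM) shows that numbers lower than that of compound 2 occur here. The estimate means this step (a 1.8-fold lower number from compound 2 to compound 4 (0.25 log units; within the scatter)). For compound 4 the estimated value is 9000 nM with an expected range of 2500 nM to 30000 nM in the same read-out.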

Compound 4, half-maximal inhibitory concentration: 13000 nM
Compound 4: middle estimate off by 1.4-fold (0.16 log units), on the low side; low and high end bracket the measured number.
By their numbers in this assay, from the lowest: compound 1; then compounds 4 and 2 (each within the scatter of the next). At a limit, above all of these: compound 3.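

In this assay, within the data shown here, (3-hydroxypropyl)carbamoyl in place of hydrogen on an amine nitrogen gives a 1.2-fold lower number from compound 2 to compound 4 (0.09 log units; within the scatter), the only step here that changes a single place. This nitrogen, whose other neighbour is an amide-type nitrogen, therefore carries a group of 7 heavy atoms with no ring, and the read-out stays within the scatter of the value with hydrogen there. Nothing measured here bears on why this step is so small.

A single step at this nitrogen cannot separate the contribution of the carbamoyl from that of the 3-hydroxypropyl chain. As far as these compounds go, the effect of an amine or a carboxylic acid in place of the hydroxy group, or of a longer chain, remains open.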